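Chain-length dependence at the aryl urea para position

The source may report more compounds than this note shows. Statements on the series, on what has been measured and on what is new or still open speak of the compounds shown alone.

Measured compounds:
- compound 1 `CCCCCCCCCCCCCc1ccc(NC(=O)Nc2c(C(C)C)cccc2C(C)C)cc1`: 11 nM
- compound 2 `CCCCCCCCc1ccc(NC(=O)Nc2c(C(C)C)cccc2C(C)C)cc1`: 11 nM
- compound 3 `CC(C)c1cccc(C(C)C)c1NC(=O)Nc1ccccc1`: 910 nM

In an assay on isolated protein for inhibition of acyl-CoA:cholesterol acyltransferase (Oryctolagus cuniculus) (on this read-out higher numbers stand for weaker inhibition and lower numbers for stronger inhibition), compound 3 gives the highest number of the three, that is, the weakest inhibition in this set. Compounds 1 and 2 sit together, and the step of no change at the digits printed from compound 1 to compound 2 (within the scatter) shows that trimming the chain from tridecyl to octyl leaves the read-out unchanged within the scatter. By contrast the step of an 83-fold higher number from compound 2 to compound 3 (1.92 log units; beyond the scatter) is large: removing the octyl group entirely from the aromatic carbon costs most of the potency.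

Compound 4 `CCCCCCCc1ccc(NC(=O)Nc2c(C(C)C)cccc2C(C)C)cc1` is not yet measured in this assay. It differs from compound 3 by heptyl in place of hydrogen on an aromatic carbon, the heptyl group entering on an aromatic carbon of a six-membered aromatic ring of carbon only, para to a large group. This is essentially the reverse of the step from compound 2 to compound 3, with a chain one carbon shorter than octyl. Both measured steps bear on it: the large loss on removing octyl, and the absence of any change between tridecyl and octyl, which suggests the read-out is insensitive to chain length once a long chain is present. A large decrease in the number, close to the level of compounds 1 and 2, is therefore expected, with the step of a 61-fold lower number from compound 3 to compound 4 (1.78 log units; beyond the scatter). For compound 4 the estimate in this assay is 15 nM, with a range of 6 nM to 40 nM.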

Compound 4, half-maximal inhibitory concentration: 19 nM
Compound 4: the middle estimate sits 1.3-fold (0.10 log units) below what was measured, within the range that was stated.
By their numbers in this assay, from the lowest: compounds 1, 2 and 4 (each within the scatter of the next); then compound 3.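

Heptyl in place of hydrogen on an aromatic carbon, para to a large group, gives a 48-fold lower number from compound 3 to compound 4 (1.68 log units; beyond the scatter) in this assay, so the large effect is not confined to octyl or tridecyl. Heptyl cannot be told apart from the longer chains, with a 1.7-fold higher number from compound 2 to compound 4 (0.24 log units; within the scatter) and a 1.7-fold higher number from compound 1 to compound 4 (0.24 log units; within the scatter) both within the scatter, which extends the flat part of the chain-length series down to heptyl across these three compounds. No independent measurement is available to explain the effect of the chain or its flat response to length.

The compounds shown leave open how short the chain can become before the read-out moves towards that of compound 3 at 910 nM, a question that butyl, ethyl or methyl on the same aromatic carbon would address. Also open, from the compounds shown here alone, is whether the chain must be all carbon and unbranched, which a heptyl-length chain ending in a carboxylic acid or an amine, or a branched chain such as 2-ethylhexyl, would test.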